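Benzylsulfonyl in Place of Trifluorophenylsulfonyl on the Core

This account rests on a few compounds, and the source may have more. Where it says the series, first, only, none or still open, it means among the compounds named here.

Compound 1 `COc1ccc(-c2cc(=O)c3c(OC)cc(OC)cc3n2Cc2ccccc2)cc1` gives > 17300 nM in a functional assay on KOPN-8 cells (Homo sapiens) for antiproliferative activity, with a stated time of 72 h (a higher number here means that more compound is needed for the effect, a lower number that less compound is needed), a limit of the assay and not a number.
Compound 2 `COc1ccc(-c2cc(=O)c3c(OC)cc(OC)cc3n2S(=O)(=O)c2cc(F)c(F)c(F)c2)cc1` gives > 65500 nM in this assay , again a limit and not a number.

Compound 2 thus stands at the limit of > 65500 nM in this assay, at which 1 of the 2 values shown sits. Among the measured compounds shown here, the only other value shown, for compound 1, is also a limit, (the limit of > 17300 nM in this assay, at which 1 of the 2 values shown sits). For the measured compounds named here, no step between measured compounds can be counted here. Compound 3 `COc1ccc(-c2cc(=O)c3c(OC)cc(OC)cc3n2S(=O)(=O)Cc2ccccc2)cc1` differs from compound 2 by benzyl in place of 3,4,5-trifluorophenyl on a sulfonyl sulfur. Since both measured values are limits, no change beyond the usual scatter is expected, and the step from compound 2 to compound 3 is estimated as an at least 1.3-fold lower number from compound 2 to compound 3 (0.11 log units; that floor lies within the scatter). Compound 3 is expected to give 50000 nM, within a range of 15000 nM to 200000 nM, most probably again reported as a limit.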

Compound 3, half-maximal effective concentration: > 34400 nM
Compound 3 was reported as a limit; the forecaster's own chance of this, stated with the estimate: 85%; the middle value does not contradict the limit.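

Compound 3 is reported only as a limit, as are compound 1 and compound 2, so its steps from compound 1 and from compound 2 cannot be read. Left open is whether benzyl and 3,4,5-trifluorophenyl on a sulfonyl sulfur differ at all in this assay.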